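Bromo to Nitrooxy: A Repeated Change and Its Expected Effect

The source may report more compounds than this note shows. Statements on the series, on what has been measured and on what is new or still open speak of the compounds shown alone.

Of the compounds shown here, three have been measured in a functional assay on the whole organism (strain albino) for inhibition, with Rattus norvegicus as the target, read by paw edema, with stated times of 30 min and 3 h, at a dose of 100 mg/kg by the oral route; on this read-out lower numbers stand for less inhibition and higher numbers for more inhibition at the one dose given (going by the name of the read-out). Compound 1 `COc1ccc(C2=NN(C(=O)CBr)C(c3c(Cl)cccc3Cl)C2)cc1` gives 7%, and compound 2 `COc1ccc(C2=NN(C(=O)CO[N+](=O)[O-])C(c3c(Cl)cccc3Cl)C2)cc1` gives 52%. The two differ in one place: nitrooxy in place of bromo on a saturated chain carbon bound to a carbonyl carbon. That change made a step of a number 45 percentage points higher from compound 1 to compound 2 (beyond the scatter).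

Compound 3 `COc1ccc(C2=NN(C(=O)C(C)Br)C(c3ccco3)C2)cc1OC` has a core that differs from that of compound 1 in a way that is not broken down here. In this assay compound 3 gives 42%; its value and that of compound 2 lie within the scatter of each other.

Compound 4 `COc1ccc(C2=NN(C(=O)C(C)O[N+](=O)[O-])C(c3ccco3)C2)cc1OC` has not yet been measured. It relates to compound 3 by the same kind of change: nitrooxy in place of bromo on a saturated chain carbon bound to a carbonyl carbon and a saturated chain carbon. The place is not identical, since here the carbon is also bound to a saturated chain carbon. Since compound 3 already gives 42%, a smaller step than before is expected, namely a number 25 percentage points higher from compound 3 to compound 4 (beyond the scatter). Compound 4 is therefore estimated to give 67%, most likely between 45% and 88%.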

Compound 4, a percentage reported as inhibition, in the whole organism at one dose (the size of the read-out at that dose, not a potency): 42%
Beside the measured number, compound 4's estimate is 25 percentage points above it; measured number outside the range, below it.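

In this assay, nitrooxy in place of bromo gave no change at the digits printed from compound 3 to compound 4 (within the scatter). The change therefore did not carry over from one core to the other with the same size: the same change on two cores in this assay, a number 45 percentage points higher (beyond the scatter) from compound 1 to compound 2 and no change at the digits printed (within the scatter) from compound 3 to compound 4, 45 percentage points apart, beyond the scatter of two such steps The two pairs differ both in the core and in the place of the change, where the carbon in compound 4 is also bound to a saturated chain carbon, and the data do not show which of these differences matters.

The compounds shown leave open what an amine or a carboxylic acid would give in place of bromo on either core. They also leave open whether nitrooxy on a longer chain would follow compound 2 or compound 4.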